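This account rests on a few compounds, and the source may have more. Where it says the series, first, only, none or still open, it means among the compounds named here.

Compound 1, `CS(=O)(=O)c1ccc(C(=O)N2CCC(C(=O)N3CCc4ccccc43)CC2)cc1[N+](=O)[O-]`, in an ADME assay on HepG2 cells (Homo sapiens) for cytotoxicity, read by CellTiter-Glo and ATP content, with a stated time of 72 h (a lower number here means that less compound is needed, a higher number that more compound is needed for the effect), gives > 27000 nM, which is a limit of the assay and not a number.
Compound 2, `Cc1ccc(N2CCN(C(=O)C3CCN(C(=O)c4ccc(S(C)(=O)=O)c([N+](=O)[O-])c4)CC3)CC2)cc1`, in this assay gives > 27000 nM, likewise a limit of the assay.
Compound 3, `CS(=O)(=O)c1ccc(C(=O)NCC(=O)N2CCCCC2)cc1[N+](=O)[O-]`, in this assay gives 14000 nM.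

Compound 2 therefore stands at a limit in this assay, and the values shown are dominated by the limit of > 27000 nM in this assay, at which 2 of the 3 values shown sit; only compound 3 gives an actual number. For the measured compounds named here, no step between measured compounds that differ in one place is available, so there is no measured step to lean on. The change to compound 4, `CN1CCN(C(=O)C2CCN(C(=O)c3ccc(S(C)(=O)=O)c([N+](=O)[O-])c3)CC2)CC1`, is methyl in place of 4-methylphenyl on an amine nitrogen in a ring, in words methyl in place of 4-methylphenyl on an amine nitrogen in a ring. With compound 2 already at a limit, no step beyond the scatter is expected in this assay in either direction, and compound 4 is expected to sit at or beyond the same limit. Compound 4 is estimated at 27000 nM, with a range from 15000 nM to 60000 nM. The step expected from compound 2 to compound 4 is a number no higher from compound 2 to compound 4 (the limit leaves the size open).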

Compound 4, half-maximal effective concentration: > 27000 nM
Compound 4: only a limit was reported; the forecaster's own chance of this, stated with the estimate: 75%; the middle value sits exactly at the limit.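

In this assay, for the compounds shown here, compound 4 gives > 27000 nM, a limit of the assay and not a number, so no step from compound 1 or compound 2 to compound 4 can be read: the limit of > 27000 nM in this assay, at which 3 of the 4 values shown sit. The compounds shown leave open how far past that limit these three lie, and so whether methyl and 4-methylphenyl on an amine nitrogen in a ring differ at all.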